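The source may hold more compounds than are shown below. What is called first, only, known or untested is meant among the compounds shown, and "the series" means these compounds.

Measured so far: compound 1 `CC1(c2ccccc2)NC(=O)N(Cc2ccc(C(=O)NO)cc2)C1=O` gives 74.9 nM in an assay on isolated protein for inhibition of protein deacetylase HDAC6 (Homo sapiens), read by fluorescence, with stated times of 10 min and 2 h (on this read-out higher numbers stand for weaker inhibition and lower numbers for stronger inhibition), and compound 2 `Cc1ccc(CC2(c3ccccc3)NC(=O)N(Cc3ccc(C(=O)NO)cc3)C2=O)cc1` gives 82.4 nM in this assay.

Of the two numbers compound 2 holds the higher, yet the step of a 1.1-fold higher number from compound 1 to compound 2 (0.04 log units; within the scatter) lies within the scatter, so the two compounds are not separated. Compound 3 `O=C(NO)c1ccc(CN2C(=O)NC(CCc3ccccc3)(c3ccccc3)C2=O)cc1` differs from compound 2 by benzyl in place of 4-methylphenyl on a saturated chain carbon bound to a saturated ring carbon. Among the compounds with values here, the only step that bears on this change is the one from compound 1 to compound 2, which added the 4-methylphenyl group without moving the number beyond the scatter. For compound 3 the expected step is therefore a 1.0-fold lower number from compound 2 to compound 3 (0.01 log units; within the scatter), none beyond the scatter. Compound 3 is estimated at 80 nM, within 40 nM to 160 nM.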

Compound 3, half-maximal inhibitory concentration: 24.7 nM
Estimate against measurement, compound 3: 3.2-fold (0.51 log units) above, and the stated range ends above it.
By their numbers in this assay, from the lowest: compound 3; then compounds 1 and 2 (each within the scatter of the next).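

This position is not indifferent to substitution: the change from 4-methylbenzyl to phenethyl gives a 3.3-fold lower number from compound 2 to compound 3 (0.52 log units; beyond the scatter) in this assay although the two groups have the same heavy-atom count, and benzyl in place of hydrogen gives a 3.0-fold lower number from compound 1 to compound 3 (0.48 log units; beyond the scatter) on the same read-out. Here the way the seven carbons are joined matters, whereas the 4-methylphenyl addition stayed within the scatter. No measurement shown accounts for this difference. The compounds shown leave open whether a longer chain, such as 3-phenylpropyl, would lower the number further, and how an amine at the end of the chain would read.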